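A few compounds are considered here, and "the series" means these few. Any claim that something is new, unique, unknown or untested is made for them only; others in the source may bear on it.

Of the compounds shown here, two have so far been measured in a functional assay on MV4-11 cells (Homo sapiens) for inhibition, read by resazurin assay, with a stated time of 72 h; a lower number here means a stronger inhibitor of growth, a higher number a weaker inhibitor of growth. Compound 1 `O=C(Nc1cccc(CN2CCCC2)c1)c1n[nH]c2ccccc12` gives 8620 nM in this assay. Compound 2 `CCc1cccc(Nc2ncc3c(n2)CCCC3)c1` gives 2600 nM in this assay, the lower of the two numbers; compound 1 is its nearest neighbour with a higher number, and that gap lies beyond the usual scatter. The two structures differ in several places at once, so nothing can be said about which part of the difference accounts for the gap.

Compound 3 `COc1cccc(Nc2ncc3c(n2)CCCC3)c1` has not yet been measured. It differs from compound 2 in one place: methoxy in place of ethyl on an aromatic carbon. Among the compounds with values here, no single-change step between measured compounds exists to set against this swap, so the expectation rests on compound 2 alone. The swap exchanges one small group for another, and the step from compound 2 to compound 3 is expected to be small, quite possibly no larger than the scatter, with a slight weakening more likely than a gain. Compound 3 is expected to give about 3400 nM in this assay, within a range from 1300 nM to 9000 nM. This corresponds to an expected step of a 1.3-fold higher number from compound 2 to compound 3 (0.12 log units; within the scatter).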

Compound 3, concentration for 50% growth inhibition: 2280 nM
Compound 3: middle estimate off by 1.5-fold (0.17 log units), on the high side; measured number inside the range.
By their numbers in this assay, from the lowest: compounds 3 and 2 (each within the scatter of the next); then compound 1.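

In this assay, methoxy in place of ethyl gives a 1.1-fold lower number from compound 2 to compound 3 (0.06 log units; within the scatter), the first single-change step available in this series, so on this evidence the two groups cannot be told apart at this position. The swap brings in an oxygen and a hydrogen-bond acceptor that ethyl lacks, on an aromatic carbon meta to a large group, yet the number stays within the scatter, so for these two groups the difference in atoms does not show up in this growth read-out. No separate measurement is available that could explain this result.

From the compounds shown here alone, with only ethyl and methoxy at this position, it remains open how a clearly different group would behave there, such as an amine, a carboxylic acid or a longer chain like butyl. Going by these compounds, it is also open whether the same swap would give a similarly small step on a different core, such as that of compound 1, or at another position on this aromatic ring.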